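The compounds below may be only part of what the source reports. "The series", "measured", "known", "first", "only" and "open" are said of these compounds alone.

Three chalcones built on a shared quinoxaline dioxide core were tested in a functional assay on CCRF-CEM cells (Homo sapiens) for inhibition, with a stated time of 3 days; a higher number here means a weaker inhibitor, a lower number a stronger inhibitor. Compound 1 `Cc1c(C(=O)/C=C/c2cccc([N+](=O)[O-])c2)[n+]([O-])c2ccccc2[n+]1[O-]` gives 15800 nM, compound 2 `COc1ccc(/C=C/C(=O)c2c(C)[n+]([O-])c3ccccc3[n+]2[O-])cc1` gives 27600 nM, and compound 3 `Cc1c(C(=O)/C=C/c2ccc(Cl)c(Cl)c2)[n+]([O-])c2ccccc2[n+]1[O-]` gives 15400 nM. The three numbers lie within the usual scatter of one another, so compound 2 cannot be set apart from compound 1 or compound 3 on this assay.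

Compound 4 `Cc1ccc(/C=C/C(=O)c2c(C)[n+]([O-])c3ccccc3[n+]2[O-])cc1` differs from compound 2 by methyl in place of methoxy on an aromatic carbon. Among the compounds with values here, the only measured step that touches the same aromatic ring is the exchange of the ring substituents from compound 2 to compound 3, which gave a 1.8-fold lower number from compound 2 to compound 3 (0.25 log units; within the scatter). That change was larger in kind than the replacement of methoxy by methyl, and it stayed within the scatter, so no step beyond the scatter is expected in this assay for compound 4.

Compound 4 is therefore expected to give about 22000 nM in this assay, within a range from 8000 nM to 60000 nM. The expected step from compound 2 to compound 4 is a 1.3-fold lower number from compound 2 to compound 4 (0.10 log units; within the scatter), which is no change beyond the scatter.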

Compound 4, half-maximal inhibitory concentration: 22400 nM
Compound 4: the middle estimate sits 1.0-fold (0.01 log units) below what was measured, within the range that was stated.
By their numbers in this assay, from the lowest: compounds 3, 1, 4 and 2 (each within the scatter of the next).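

In this assay, the position para to a large group on the aromatic ring accepts methyl in place of methoxy with a 1.2-fold lower number from compound 2 to compound 4 (0.09 log units; within the scatter) as the only result, so losing the oxygen and its hydrogen-bond acceptor opens no gap at this site. The 4-methylphenyl group likewise gives a 1.5-fold higher number from compound 3 to compound 4 (0.16 log units; within the scatter) when it replaces the 3,4-dichlorophenyl group, which means that a single small carbon substituent at this position cannot be told apart from the dichloro pattern. No measurement available here explains why these numbers stay so close.

On these data alone, whether an amine or a carboxylic acid at the same ring position would give a step beyond the scatter remains open. So does the effect of a longer chain there, such as ethyl or propyl in place of the methyl of compound 4.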